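A few compounds are considered here, and "the series" means these few. Any claim that something is new, unique, unknown or untested is made for them only; others in the source may bear on it.

Series notes, cytotoxicity set

Three compounds of this set have been run in an ADME assay on C8166 cells (Homo sapiens) for cytotoxicity, read by colorimetric assay and MTT assay; a higher number here means that more compound is tolerated, a lower number that less compound is tolerated. Compound 1 `Cc1cccc(C(=O)c2c(OCC(=O)Nc3ccc(S(N)(=O)=O)cc3C)ccc3ccccc23)c1` is the parent; in this assay compound 1 gives 40400 nM. Compound 2 `Cc1cc(S(N)(=O)=O)ccc1NC(=O)COc1ccc2ccccc2c1C(=O)c1cccc(Cl)c1` carries chloro in place of methyl on an aromatic carbon and gives 37400 nM in this assay; the step of a 1.1-fold lower number from compound 1 to compound 2 (0.03 log units; within the scatter) is a flat one. Compound 3 `Cc1cccc(C(=O)c2c(OCC(=O)Nc3ccc(S(N)(=O)=O)cc3C)ccc3cc(C#N)ccc23)c1` carries cyano in place of hydrogen on an aromatic carbon on the core and gives 15200 nM in this assay; here the step of a 2.7-fold lower number from compound 1 to compound 3 (0.42 log units; beyond the scatter) is the only one in the set that reaches beyond the scatter, and compound 3 stands at the low end of the three values, with compound 2 and compound 1 both beyond the scatter above it.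

Compound 4 `Cc1cc(S(N)(=O)=O)ccc1NC(=O)COc1ccc2cc(C#N)ccc2c1C(=O)c1cccc(Cl)c1` has not yet been run in this assay. It differs from compound 3 by chloro in place of methyl on an aromatic carbon, which is the same change that separates compound 2 from compound 1, made on the core of compound 3 rather than on the core of compound 1; the two cores differ by cyano in place of hydrogen on an aromatic carbon. The change occurs twice in the set, once measured and once pending.

For the measured compounds named here, the single precedent is the flat step a 1.1-fold lower number from compound 1 to compound 2 (0.03 log units; within the scatter). The step of a 1.1-fold lower number from compound 3 to compound 4 (0.04 log units; within the scatter) is expected to be about as flat, with the expected value resting on compound 3 at 15200 nM as the anchor. Compound 4 is thus estimated at 14000 nM in this assay, with an expected range from 7000 nM to 28000 nM. Whether the cyano-bearing core shifts the outcome of this change is not known from the data; the measurement will tell.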

Compound 4, half-maximal cytotoxic concentration: > 374000 nM
Compound 4 gave a limit, no number (the forecaster's own chance of this, stated with the estimate: 5%); middle value at least 26-fold (1.42 log units) from the limit.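

In this assay compound 4 gives > 374000 nM which is a limit of the assay and not a number. Chloro in place of methyl does not carry from the core of compound 1 to the cyano-bearing core, where the change gives an at least 24-fold higher number from compound 3 to compound 4 (1.39 log units; beyond the scatter) and so does not repeat the flat step seen on the core of compound 1: the same change on two cores in this assay, a 1.1-fold lower number (0.03 log units; within the scatter) from compound 1 to compound 2 and an at least 24-fold higher number (1.39 log units; beyond the scatter) from compound 3 to compound 4, at least 26-fold (1.42 log units) apart, beyond the scatter of two such steps. Read through the other change, the cyano group gives an at least 10-fold higher number from compound 2 to compound 4 (1.00 log units; beyond the scatter) on the chloro-bearing compounds, the opposite direction to its step on the core of compound 1, but this one square of four compounds does not show why the two changes fail to add, how far the step truly runs, or whether the same would hold on any other core: the same change on two cores in this assay, a 2.7-fold lower number (0.42 log units; beyond the scatter) from compound 1 to compound 3 and an at least 10-fold higher number (1.00 log units; beyond the scatter) from compound 2 to compound 4, at least 26-fold (1.42 log units) apart, beyond the scatter of two such steps.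

The compounds shown leave open whether the large step needs the nitrile itself or would also appear with another group at that place on the shared core. An amine or a carboxylic acid there, each paired with the 3-methylphenyl and the 3-chlorophenyl groups, would put that question to the test.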